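Swapping the chain aryl group under a shared cytotoxicity ceiling

A few compounds are considered here, and "the series" means these few. Any claim that something is new, unique, unknown or untested is made for them only; others in the source may bear on it.

Compound 1 `Cc1ccc(-c2c3c(nc(C)c2[C@H](OC(C)(C)C)C(=O)O)CCN(c2ccc(-c4ccccc4)cc2)C3)cc1`: in an ADME assay on MT2 cells (Homo sapiens) for cytotoxicity, read by XTT assay, with a stated time of 4 days (a higher number here means that more compound is tolerated, a lower number that less compound is tolerated), compound 1 gives > 40000 nM, a limit of the assay and not a number.
Compound 2 `Cc1ccc(-c2c3c(nc(C)c2[C@H](OC(C)(C)C)C(=O)O)CCN(C(=O)OCc2ccccc2)C3)cc1`: in this assay compound 2 gives > 40000 nM, again a limit of the assay.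
Compound 3 `Cc1ccc(CCCN2CCc3nc(C)c([C@H](OC(C)(C)C)C(=O)O)c(-c4cc(F)c5c(c4C)CCCO5)c3C2)cc1F`: in this assay compound 3 gives > 40000 nM, once more a limit of the assay.

All three measured compounds sit at the same ceiling, as the evidence the limit of > 40000 nM in this assay, at which 3 of the 3 values shown sit, records. Going by the values given here, the only measured step between compounds differing in one place, a step that the two limits leave unreadable from compound 1 to compound 2, is unreadable for that reason. Compound 3 therefore stands only at a limit in this assay, with no number to rank it against the other two.

Compound 4 `Cc1ccccc1CCCN1CCc2nc(C)c([C@H](OC(C)(C)C)C(=O)O)c(-c3cc(F)c4c(c3C)CCCO4)c2C1` differs from compound 3 as 2-methylphenyl in place of 3-fluoro-4-methylphenyl on a saturated chain carbon, three bonds along the chain from an amine nitrogen in a ring. Among the compounds with values here, no measured step bears on this change, and the one measured step is itself unreadable, so nothing points to a readable move in either direction. Compound 4 is expected to stay at the ceiling as well: its estimated value in this assay is 60000 nM, within 30000 nM to 150000 nM, and the expected step that the limit leaves unreadable from compound 3 to compound 4 is one that the limit would most likely leave unreadable.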

Compound 4, half-maximal cytotoxic concentration: > 40000 nM
Compound 4: a limit, no number; the forecaster's own chance of this, stated with the estimate: 85%; the middle value does not contradict the limit.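

In this assay compound 4 gives > 40000 nM, again a limit of the assay and not a number. With compound 3 also at a limit, no step can be read between compound 3 and compound 4. The compounds shown leave open where the half-maximal cytotoxic concentration of any of them actually lies.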